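This account rests on a few compounds, and the source may have more. Where it says the series, first, only, none or still open, it means among the compounds named here.

Three compounds share one core and were measured in a physicochemical assay for solubility, at pH 6.5; on this read-out lower numbers stand for lower solubility and higher numbers for higher solubility. Compound 1 `Cc1cc(Nc2ccc(C(F)(F)F)cc2)n2nc(C3CC3)nc2n1` gives 38000 nM. Compound 2 `Cc1cc(Nc2ccc(C(F)(F)F)cc2)n2nc(CCO)nc2n1` gives 19000 nM, and compound 3 `CSc1nc2nc(C)cc(Nc3ccc(S(F)(F)(F)(F)F)cc3)n2n1` gives 7800 nM. Among the measured compounds shown here, compound 2 therefore stands second highest of the three: the one single-place step, a 2.0-fold lower number from compound 1 to compound 2 (0.30 log units; within the scatter), lies within the scatter, while compound 3 sits beyond the scatter below compound 2.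

Compound 4 `COCCc1nc2nc(C)cc(Nc3ccc(C(F)(F)F)cc3)n2n1` differs from compound 2 by methyl in place of hydrogen on an oxygen on a saturated carbon. For the measured compounds named here, no measured step alters an oxygen in this way; the only measured step touched the same chain and stayed within the scatter. Compound 4 is therefore expected to change little, a 1.3-fold lower number from compound 2 to compound 4 (0.10 log units; within the scatter). The estimate for compound 4 is 15000 nM, with a range from 6000 nM to 40000 nM.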

Compound 4, solubility: 71000 nM
Beside the measured number, compound 4's estimate is 4.7-fold (0.68 log units) below it; measured number above the stated range.
By their numbers in this assay, from the lowest: compound 3; then compounds 2, 1 and 4 (each within the scatter of the next, the first and the last beyond it).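

In this assay, among the compounds shown here, hydroxy to methoxy at the end of the chain gives a 3.7-fold higher number from compound 2 to compound 4 (0.57 log units; beyond the scatter), the only step at this position that lies beyond the scatter, so a single added methyl on this oxygen can matter even though the earlier step from cyclopropyl did not. The other step, a 1.9-fold higher number from compound 1 to compound 4 (0.27 log units; within the scatter), stays within the scatter, so 2-methoxyethyl and cyclopropyl on this aromatic carbon cannot be told apart. Nothing available explains the step from hydroxy to methoxy. Still open, on these data alone, is how a longer ether chain or an amine at the chain end would compare with 2-methoxyethyl.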